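This account rests on a few compounds, and the source may have more. Where it says the series, first, only, none or still open, it means among the compounds named here.

Of the compounds shown here, two have been measured so far. Compound 1 `Clc1ccc(-c2nc3occn3c2/C=N/OCc2ccc(Cl)c(Cl)c2)cc1` gives 410 nM in an assay on HepG2 cells for agonist activity at nuclear receptor subfamily 1 group I member 3 (Homo sapiens), read by a luciferase reporter, with a stated time of 23 h; a higher number here means that more compound is needed for the effect, a lower number that less compound is needed. Compound 2 `Clc1cccc(-c2nc3sccn3c2/C=N/OCc2ccc(Cl)c(Cl)c2)c1` gives 1100 nM in this assay, which is the highest of the two numbers; its gap to compound 1 is beyond the usual scatter, so compound 2 needs more material for the same effect. The two differ in more than one place, so nothing can be said about the effect of a single change between them.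

Compound 3 `Cc1ccc(-c2nc3sccn3c2/C=N/OCc2ccc(Cl)c(Cl)c2)cc1` has not yet been measured in this assay. It differs from compound 2 in one place, (4-methylphenyl in place of 3-chlorophenyl on an aromatic carbon), on an aromatic carbon of the shared core. Among the measured compounds shown here, no single-change step between measured compounds is available to guide the expectation, so the estimate rests on the scale set by compound 1 and compound 2 alone. A modest step toward a lower number is expected, a 1.6-fold lower number from compound 2 to compound 3 (0.20 log units; within the scatter). Compound 3 is therefore estimated at 700 nM, within a range from 250 nM to 2200 nM.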

Compound 3, half-maximal effective concentration: 490 nM
Compound 3: middle estimate off by 1.4-fold (0.15 log units), on the high side, within the range that was stated.
By their numbers in this assay, from the lowest: compounds 1 and 3 (each within the scatter of the next); then compound 2.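

In this assay, putting 4-methylphenyl in place of 3-chlorophenyl on this aromatic carbon of the shared core gives a 2.2-fold lower number from compound 2 to compound 3 (0.35 log units; beyond the scatter), the first single-change step available here. The step is modest but beyond the scatter, so the group at this place affects how much compound is needed, even though both groups keep the same six-membered aromatic ring and the same heavy-atom count. Nothing at hand explains why the number falls.

The change removes a chlorine and brings in a methyl, and the group's attachment number also shifts from 3 to 4, so these parts of the change cannot be separated here. A 3-methylphenyl or an unsubstituted phenyl group at this place would help separate them, and a 4-methoxyphenyl group would test a different substituent.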